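The compounds below may be only part of what the source reports. "The series", "measured", "known", "first", "only" and "open" are said of these compounds alone.

Compound 1 `Clc1ncc(OC[C@@H]2CCN2)cc1-c1ccc(Br)nc1` and compound 2 `Clc1ncc(OC[C@@H]2CCCN2)cc1-c1ccc(Br)nc1` share one core. In an assay on membranes from brain with Neuronal acetylcholine receptor; alpha4/beta2 (Rattus norvegicus) as the target (on this read-out lower numbers stand for stronger inhibition and higher numbers for weaker inhibition), compound 1 gives 0.0043 nM, and compound 2 gives 0.0195 nM. The change between them is pyrrolidin-2-yl in place of azetidin-2-yl on a saturated chain carbon bound to an oxygen on an aromatic ring, and it produced a 4.5-fold higher number from compound 1 to compound 2 (0.66 log units; beyond the scatter).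

Compound 3 `Fc1cc(/C=C/c2cc(OC[C@@H]3CCN3)cnc2Cl)ccn1` is built on a different core; the difference between the two cores is not broken down here. In this assay compound 3 gives 0.0031 nM, a number close to that of compound 1.

Compound 4 `Fc1cc(/C=C/c2cc(OC[C@@H]3CCCN3)cnc2Cl)ccn1` has not yet been measured in this assay. Among the compounds with values here, it differs from compound 3 by pyrrolidin-2-yl in place of azetidin-2-yl on a saturated chain carbon bound to an oxygen on an aromatic ring, the same change as the one from compound 1 to compound 2. Within the data shown here, the step is expected to be of similar size, a 4.5-fold higher number from compound 3 to compound 4 (0.65 log units; beyond the scatter), because a 4.5-fold higher number from compound 1 to compound 2 (0.66 log units; beyond the scatter) is the only measured example of this change. Compound 4 is therefore expected to give 0.014 nM, most likely between 0.006 nM and 0.035 nM.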

Compound 4, inhibition constant: 0.0094 nM
Compound 4: middle estimate off by 1.5-fold (0.17 log units), on the high side; low and high end bracket the measured number.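

Putting pyrrolidin-2-yl in place of azetidin-2-yl on the second core, in this assay, gives a 3.0-fold higher number from compound 3 to compound 4 (0.48 log units; beyond the scatter) and so again weakens binding. The size of this step agrees with that of the earlier one: the same change on two cores in this assay, a 4.5-fold higher number (0.66 log units; beyond the scatter) from compound 1 to compound 2 and a 3.0-fold higher number (0.48 log units; beyond the scatter) from compound 3 to compound 4, 1.5-fold (0.17 log units) apart, within the scatter of two such steps. The change therefore carried over in direction and in size between these two cores, but two pairs cannot show that it will hold on a third core, and they do not explain why the number rises.

The compounds shown leave open what a piperidin-2-yl group would do in the same place. They also leave open whether a longer chain in place of the single saturated carbon would keep binding this strong.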